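Shifting Two Fluorines on the Aryl Ring of Compound 3

The source may hold more compounds than are shown below. What is called first, only, known or untested is meant among the compounds shown, and "the series" means these compounds.

Three close analogues of one core have been measured in a functional assay on CHO cells for agonist activity at metabotropic glutamate receptor 2 (Homo sapiens), read by scintillation counting and GTPgammaS binding, with a stated time of 30 min; a higher number here means that more compound is needed for the effect, a lower number that less compound is needed. Compound 1 `COc1ccc(F)cc1C1CCN(c2ccn3c(CC4CC4)nnc3c2Cl)CC1` gives 8.2 nM in this assay. Compound 2 `COc1cccc(F)c1C1CCN(c2ccn3c(CC4CC4)nnc3c2Cl)CC1` gives 6 nM, and the step of a 1.4-fold lower number from compound 1 to compound 2 (0.14 log units; within the scatter) stays within the scatter. Compound 3 `COc1c(F)ccc(F)c1C1CCN(c2ccn3c(CC4CC4)nnc3c2Cl)CC1` gives 7.5 nM; the steps of a 1.1-fold lower number from compound 1 to compound 3 (0.04 log units; within the scatter) and a 1.3-fold higher number from compound 2 to compound 3 (0.10 log units; within the scatter) likewise remain within the scatter, so compound 3 stands among three numbers that cannot be told apart, its nearest neighbour being compound 1 and its furthest compound 2.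

Compound 4 `COc1cc(F)cc(F)c1C1CCN(c2ccn3c(CC4CC4)nnc3c2Cl)CC1` has not yet been measured in this assay. It differs from compound 3 by 2,4-difluoro-6-methoxyphenyl in place of 3,6-difluoro-2-methoxyphenyl on a saturated ring carbon; the two compounds have the same atoms, joined differently. Every rearrangement of fluoro and methoxy on this aryl ring seen so far, from compound 1 to compound 2 and on to compound 3, has left this assay unmoved beyond the scatter. On that basis compound 4 is expected to show no step beyond the scatter, no change at the digits printed from compound 3 to compound 4 (within the scatter), and its estimated value is 7.5 nM with a range from 3 nM to 19 nM.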

Compound 4, half-maximal effective concentration: 6.9 nM
For compound 4 the middle estimate is 1.1-fold (0.04 log units) above the measured one; measured number inside the range.
By their numbers in this assay, from the lowest: compounds 2, 4, 3 and 1 (each within the scatter of the next).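

The 2,4-difluoro-6-methoxyphenyl group gives a 1.1-fold lower number from compound 3 to compound 4 (0.04 log units; within the scatter) in this assay, which shows that a further arrangement of the same atoms on the aryl ring, at the same saturated ring carbon, also stays within the scatter. Fluoro in place of hydrogen at a new aromatic carbon likewise gives a 1.2-fold higher number from compound 2 to compound 4 (0.06 log units; within the scatter) and remains within the scatter, while the step of a 1.2-fold lower number from compound 1 to compound 4 (0.07 log units; within the scatter) completes a set of four compounds that cannot be told apart. No evidence is available to explain this result.

All four compounds keep a methoxy group and at least one fluoro on the aryl ring. On these data alone, what an amine or a carboxylic acid in place of the methoxy group would do at this position therefore stays open.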